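Bromo analogue of compound 2: expected cytotoxicity

The source may report more compounds than this note shows. Statements on the series, on what has been measured and on what is new or still open speak of the compounds shown alone.

Measured so far in a functional assay on HeLa cells (Homo sapiens) for cytotoxicity, read by XTT assay, with a stated time of 24 h; a higher number here means a weaker inhibitor, a lower number a stronger inhibitor:
compound 1 `Cc1cc(O)c2c(c1Cl)C(=O)C=CC2=O` gives 13500 nM
compound 2 `Cc1cc(O)c2c(c1F)C(=O)C=CC2=O` gives 10200 nM
compound 3 `CC(=O)Oc1c(C)cc(Cl)c2c1C(=O)C=CC2=O` gives 21800 nM

Compound 2 has the lowest number of the three; compound 1 lies within the scatter of it, whereas compound 3 lies beyond it. Compound 4 `Cc1cc(O)c2c(c1Br)C(=O)C=CC2=O` is not yet measured. It differs from compound 2 in one place: bromo in place of fluoro on an aromatic carbon. Among the measured compounds shown here, the only measured step that bears on this exchange is a 1.3-fold lower number from compound 1 to compound 2 (0.12 log units; within the scatter), which stayed within the scatter. A further exchange of this kind is therefore expected to give no step beyond the scatter in this assay, with compound 4 expected to land near compound 1 and compound 2. Compound 4 is estimated at 12000 nM, range 6000 nM to 25000 nM. The expected step is a 1.2-fold higher number from compound 2 to compound 4 (0.07 log units; within the scatter).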

Compound 4, half-maximal inhibitory concentration: 11300 nM
For compound 4 the middle estimate is 1.1-fold (0.03 log units) above the measured one, within the range that was stated.
By their numbers in this assay, from the lowest: compounds 2, 4, 1 and 3 (each within the scatter of the next, the first and the last beyond it).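

In this assay the aromatic carbon para to the hydroxy group now carries fluoro, chloro or bromo: bromo in place of fluoro gives a 1.1-fold higher number from compound 2 to compound 4 (0.04 log units; within the scatter) and bromo in place of chloro gives a 1.2-fold lower number from compound 1 to compound 4 (0.08 log units; within the scatter) and both steps stay within the scatter. Compound 1, compound 2 and compound 4 therefore cannot be separated, so across these three halogens the exchange leaves the number unresolved. No measurement available here explains this agreement.

From the compounds shown here alone, whether this holds beyond halogens remains open: an amine, a methoxy group or a carboxylic acid on this carbon could still shift the number.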